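Urea-linked pyrazole series: cell growth read-out at one concentration

The compounds below may be only part of what the source reports. "The series", "measured", "known", "first", "only" and "open" are said of these compounds alone.

Measured compounds:
compound 1 `COc1cc(Cl)cc(-c2nn(-c3cccc(NC(=O)Nc4cc(C(F)(F)F)cc(C(F)(F)F)c4)c3)cc2-c2ccncc2)c1` — 100%
compound 2 `COc1cc(Cl)cc(-c2nn(-c3cccc(NC(=O)Nc4ccc(Cl)c(Cl)c4)c3)cc2-c2ccncc2)c1` — 100%

In a functional assay on SK-OV-3 cells (Homo sapiens) for inhibition, read by sulforhodamine B assay, with a stated time of 48 h, tested at 0.01 uM (on this read-out lower numbers stand for a stronger effect and higher numbers for a weaker effect at the one concentration tested), compound 1 gives 100% and compound 2 gives 100%. Compound 2 therefore stands level with compound 1 at the digits shown; the two values lie within the scatter, so no order between them can be stated. Both read-outs sit at the top of the scale in this assay, which is to say that at this concentration neither compound shows an effect.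

Compound 3 `COc1cc(Cl)cc(-c2nn(-c3cccc(NC(=O)Nc4cccc(C(F)(F)F)c4)c3)cc2-c2ccncc2)c1` has not yet been measured in this assay. It differs from compound 2 in one place: 3-(trifluoromethyl)phenyl in place of 3,4-dichlorophenyl on an amide-type nitrogen

Within the data shown here, no step between measured compounds exists for this change, so its size cannot be read from the data. Since compound 1 and compound 2 both give no effect at this concentration, compound 3 is expected to behave the same way, and the expected step of a number 1 percentage points lower from compound 2 to compound 3 (within the scatter) is none beyond the scatter. Compound 3 is estimated at 99% in this assay, with a range from 85% to 110%.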

Compound 3, a percentage reported as activity, at one concentration (the size of the read-out at that concentration, not a potency): 92%
Beside the measured number, compound 3's estimate is 7 percentage points above it; low and high end bracket the measured number.
By their numbers in this assay, from the lowest: compounds 3, 1 and 2 (each within the scatter of the next).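

In this assay, among these compounds, the first measured change on this aryl group, 3-(trifluoromethyl)phenyl in place of 3,4-dichlorophenyl on an amide-type nitrogen, gives a number 8 percentage points lower from compound 2 to compound 3 (within the scatter), so the exchange cannot be told apart from no change at this one concentration. Hydrogen in place of trifluoromethyl on an aromatic carbon gives a number 8 percentage points lower from compound 1 to compound 3 (within the scatter), so this edit also yields no separable effect, and the three aryl groups shown cannot be ranked. No supporting measurement bears on either step.

The compounds shown leave open whether an aryl group carrying an amine or a carboxylic acid on the amide-type nitrogen would move the read-out beyond the scatter. They also leave open whether these three compounds would separate at a higher concentration.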